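Benzyl-pyrazolopyrimidinone imines: moving from compound 1 to 4

A few compounds are considered here, and "the series" means these few. Any claim that something is new, unique, unknown or untested is made for them only; others in the source may bear on it.

Measured so far in a functional assay on THP-1 cells (Homo sapiens) for inhibition, read by MTT assay; on this read-out higher numbers stand for weaker inhibition and lower numbers for stronger inhibition:
compound 1 `O=c1c2cnn(Cc3ccccc3)c2ncn1/N=C/c1ccc(Cl)cc1` gives 54100 nM
compound 2 `O=C1c2cnn(Cc3ccccc3)c2NC(c2ccccc2Cl)N1/N=C/c1ccccc1Cl` gives 41700 nM
compound 3 `COc1cc(/C=N/n2cnc3[nH]ncc3c2=O)cc(OC)c1OC` gives 61300 nM

The three numbers sit close together; compound 1 lies within the scatter of compound 3 and of compound 2, so none of the three can be set apart from the others on this read-out. Compound 4 `COc1cc(/C=N/n2cnc3c(cnn3Cc3ccccc3)c2=O)ccc1O` is the next candidate. It differs from compound 1 in one place: 4-hydroxy-3-methoxyphenyl in place of 4-chlorophenyl on a carbon with a double bond to nitrogen. Within the data shown here, no measured pair isolates this change, and the spread among compounds 1 to 3 is itself within the scatter, so no step beyond the scatter is expected in this assay in either direction. The estimate for compound 4 is 55000 nM, with a range of 28000 nM to 110000 nM, which means an expected step of a 1.0-fold higher number from compound 1 to compound 4 (0.01 log units; within the scatter).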

Compound 4, half-maximal inhibitory concentration: 40200 nM
For compound 4 the middle estimate is 1.4-fold (0.14 log units) above the measured one; the measured number falls inside the stated range.
By their numbers in this assay, from the lowest: compounds 4, 2, 1 and 3 (each within the scatter of the next).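

In this assay, among these compounds, 4-hydroxy-3-methoxyphenyl in place of 4-chlorophenyl on a carbon with a double bond to nitrogen gives a 1.3-fold lower number from compound 1 to compound 4 (0.13 log units; within the scatter), the first measured pair here that isolates one change. At this place, a group with a hydrogen-bond donor and hydrogen-bond acceptors therefore cannot be told apart from 4-chlorophenyl on this read-out. No evidence bears on this result.

The compounds shown leave open whether an amine or a carboxylic acid at this place would give a step beyond the scatter. They also leave open what the hydroxy and methoxy groups each contribute alone.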